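Methoxymethoxy analogues in a cytotoxicity series

A few compounds are considered here, and "the series" means these few. Any claim that something is new, unique, unknown or untested is made for them only; others in the source may bear on it.

Compound 1 `COc1ccccc1C(=O)/C=C/c1ccc2c(c1)B(O)OC2` and compound 2 `COc1cccc(C(=O)/C=C/c2ccc3c(c2)B(O)OC3)c1` are built from the same atoms joined differently; the difference between the two cores is not broken down here. In a toxicity assay on WI-38 cells (Homo sapiens) for cytotoxicity, read by MTT assay, with a stated time of 48 h (on this read-out higher numbers stand for weaker inhibition and lower numbers for stronger inhibition), compound 1 gives 21700 nM, and compound 2 gives 14600 nM, the two lying within the scatter of each other. Compound 3 `COCOc1ccccc1C(=O)/C=C/c1ccc2c(c1)B(O)OC2` carries methoxy in place of hydrogen on a saturated chain carbon bound to an oxygen on an aromatic ring relative to compound 1, and in this assay compound 3 gives 27000 nM, which is a 1.2-fold higher number from compound 1 to compound 3 (0.09 log units; within the scatter). Compound 4 `COCOc1cccc(C(=O)/C=C/c2ccc3c(c2)B(O)OC3)c1` is not yet measured; it carries methoxy in place of hydrogen on a saturated chain carbon bound to an oxygen on an aromatic ring relative to compound 2, the same change as the one from compound 1 to compound 3, which occurs twice among these compounds. The step from compound 2 to compound 4 in this assay is expected to be a 1.2-fold higher number from compound 2 to compound 4 (0.08 log units; within the scatter), matching a 1.2-fold higher number from compound 1 to compound 3 (0.09 log units; within the scatter) in size. That expectation rests on the step of a 1.2-fold higher number from compound 1 to compound 3 (0.09 log units; within the scatter) having stayed within the scatter. For compound 4 in this assay the estimate is 17500 nM, with a range from 9000 nM to 35000 nM.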

Compound 4, half-maximal inhibitory concentration: 33200 nM
Compound 4: the middle estimate sits 1.9-fold (0.28 log units) below what was measured, and the stated range covers the measured number.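

In this assay the change of hydrogen to methoxy gives a 2.3-fold higher number from compound 2 to compound 4 (0.36 log units; beyond the scatter) and is a modest step, yet it does not separate from the same change on the core of compound 1: the same change on two cores in this assay, a 1.2-fold higher number (0.09 log units; within the scatter) from compound 1 to compound 3 and a 2.3-fold higher number (0.36 log units; beyond the scatter) from compound 2 to compound 4, 1.8-fold (0.26 log units) apart, within the scatter of two such steps. On these two cores, then, nothing indicates that the core alters the outcome of this change. For the compounds shown here, this does not show that the change acts equally on both cores, or on any other core: only two pairs stand here, one step within the scatter and the other beyond it.

Still open, as far as these compounds go, is whether a longer chain such as ethoxy, or an amine or a carboxylic acid, in place of methoxy on the same saturated chain carbon would give a step of similar size. Also open, from the compounds shown here alone, is how this change behaves in cells other than those of this assay.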